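Phenyl for Pyridin-3-yl at the Amide Carbonyl

A few compounds are considered here, and "the series" means these few. Any claim that something is new, unique, unknown or untested is made for them only; others in the source may bear on it.

Compound 1 `Cc1ccc(S(=O)(=O)NCc2ccc(CNC(=O)c3ccc(F)cc3)cc2)cc1` gives 1 nM in an assay on MDA-MB-231 cells for binding affinity to C-X-C chemokine receptor type 4 (Homo sapiens), read by immunofluorescence and microscopy, with stated times of 10 min and 30 min; on this read-out higher numbers stand for an effect only at larger amounts of compound and lower numbers for an effect already at smaller amounts.
Compound 2 `COc1ccc(C(=O)NCc2ccc(CNS(=O)(=O)c3ccc(C)cc3)cc2)cc1` gives 100 nM in this assay.
Compound 3 `O=C(NCc1ccc(CNS(=O)(=O)c2ccccc2)cc1)c1cccnc1` gives 10 nM in this assay.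

Compound 3 stands second highest of the three numbers: compound 1 lies below it and compound 2 above it, both beyond the scatter. Compound 4 `O=C(NCc1ccc(CNS(=O)(=O)c2ccccc2)cc1)c1ccccc1` differs from compound 3 in one place, (phenyl in place of pyridin-3-yl on a carbonyl carbon). Among the compounds with values here, the only measured step, a 100-fold higher number from compound 1 to compound 2 (2.00 log units; beyond the scatter), concerns a substituent on an aromatic carbon and leaves the ring itself unchanged, so no measured step speaks directly to an exchange of the ring. With no guide of that kind, the number of compound 3 is the best anchor. Compound 4 is therefore expected to give about 10 nM, between 3 nM and 30 nM, a step of no change at the digits printed from compound 3 to compound 4 (within the scatter) expected to stay within the scatter.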

Compound 4, effective concentration (reported as EC, without a stated level of effect): 1 nM
The estimate for compound 4 lay 10-fold (1.00 log units) above the measured number; measured number below the stated range.
By their numbers in this assay, from the lowest: compounds 1 and 4 (each within the scatter of the next); then compound 3; then compound 2.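

In this assay, the ring on the carbonyl carbon itself proves to matter: the exchange gives a 10-fold lower number from compound 3 to compound 4 (1.00 log units; beyond the scatter). The earlier step changed only a substituent on an aromatic carbon, whereas here a ring with one hetero atom gives way to a ring of carbon only. Nothing measured here accounts for this step. From the compounds shown here alone, whether pyridin-4-yl or cyclohexyl on the same carbonyl carbon would track with phenyl or with pyridin-3-yl stays open. So does whether an amine on the phenyl ring would keep the number of compound 4 1 nM.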